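Working notes: replacing 4-nitrophenyl with heptyl

A few compounds are considered here, and "the series" means these few. Any claim that something is new, unique, unknown or untested is made for them only; others in the source may bear on it.

Values in a functional assay on A549 cells (Homo sapiens) for inhibition, read by MTT assay, with a stated time of 48 h (on this read-out higher numbers stand for weaker inhibition and lower numbers for stronger inhibition), so far
- compound 1 `Oc1ccc(C(c2c[nH]c3ccc(Br)cc23)c2c[nH]c3ccc(Br)cc23)cc1` gives 9000 nM
- compound 2 `COc1ccc(C(c2c[nH]c3ccc(Br)cc23)c2c[nH]c3ccc(Br)cc23)cc1` gives 10000 nM
- compound 3 `O=[N+]([O-])c1ccc(C(c2c[nH]c3ccc(Br)cc23)c2c[nH]c3ccc(Br)cc23)cc1` gives 5500 nM

Compound 3 holds the lowest number of the three, yet a 1.6-fold lower number from compound 1 to compound 3 (0.21 log units; within the scatter) and a 1.8-fold lower number from compound 2 to compound 3 (0.26 log units; within the scatter) leave it level with the others within the scatter. Compound 4 `CCCCCCCC(c1c[nH]c2ccc(Br)cc12)c1c[nH]c2ccc(Br)cc12` is unmeasured. Its change from compound 3 is heptyl in place of 4-nitrophenyl on a saturated chain carbon bound to two aromatic carbons, so heptyl in place of 4-nitrophenyl on a saturated chain carbon bound to two aromatic carbons. The nearest evidence is those two steps and a 1.1-fold higher number from compound 1 to compound 2 (0.05 log units; within the scatter), all small. Among the measured compounds shown here, each swaps a group on the aromatic ring, and none removes that ring, so the data hold no direct precedent. No step beyond the scatter is expected in this assay, and the estimated change is a 1.3-fold higher number from compound 3 to compound 4 (0.10 log units; within the scatter) with real uncertainty. For compound 4 the estimate is 7000 nM, with 2500 nM to 20000 nM as the expected range.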

Compound 4, half-maximal inhibitory concentration: 3500 nM
The estimate for compound 4 lay 2.0-fold (0.30 log units) above the measured number, and the stated range covers the measured number.
By their numbers in this assay, from the lowest: compounds 4, 3, 1 and 2 (each within the scatter of the next, the first and the last beyond it).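

Heptyl in place of 4-nitrophenyl gives a 1.6-fold lower number from compound 3 to compound 4 (0.20 log units; within the scatter) and so shows that an aromatic ring on this carbon is not needed to hold activity in this assay. Against the other two aryl groups, the change is a modest gain beyond the scatter, with a 2.9-fold lower number from compound 2 to compound 4 (0.46 log units; beyond the scatter) and a 2.6-fold lower number from compound 1 to compound 4 (0.41 log units; beyond the scatter) as the steps. No evidence on hand accounts for this result.

Open, going by these compounds, is whether a longer chain, a shorter chain such as butyl, or a heptyl chain ending in an amine or a carboxylic acid would move the number further.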